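The source may report more compounds than this note shows. Statements on the series, on what has been measured and on what is new or still open speak of the compounds shown alone.

The measured compounds, in brief:

Compound 1 `CCC1(Cc2ccccc2)OS(=O)(=O)C=C1OCc1ccccc1Cl`; in an ADME assay on HEL cells (Homo sapiens) for cytotoxicity, with a stated time of 3 days (a higher number here means that more compound is tolerated, a lower number that less compound is tolerated), compound 1 gives >= 20000 nM, a limit of the assay.
Compound 2 `CCC1(Cc2ccccc2)OS(=O)(=O)C=C1OCCCc1ccccc1`; in this assay compound 2 gives >= 20000 nM, again a limit.
Compound 3 `CCC1(Cc2ccccc2)OS(=O)(=O)C=C1OCc1ccc(Br)cc1`; in this assay compound 3 gives 80000 nM.

Among the compounds with values here, compound 3 thus holds the only number among the three; the other two values sit at the limit of >= 20000 nM in this assay, at which 2 of the 3 values shown sit. Within the data shown here, the steps a step that the limit leaves unreadable from compound 1 to compound 3 and a step that the limit leaves unreadable from compound 2 to compound 3 are therefore unreadable in size, and no measured step touches a group on the six-membered aromatic ring of carbon only.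

Compound 4 `CCC1(Cc2ccccc2)OS(=O)(=O)C=C1OCc1ccc(C(C)(C)C)cc1` differs from compound 3 by tert-butyl in place of bromo on an aromatic carbon. Among the measured compounds shown here, with no step to draw on, the expectation rests on compound 3 alone, and the step from compound 3 to compound 4 is expected to stay within the scatter: a 1.1-fold lower number from compound 3 to compound 4 (0.06 log units; within the scatter). Compound 4 is estimated at 70000 nM, between 20000 nM and 200000 nM.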

Compound 4, minimum cytotoxic concentration: >= 400000 nM
Compound 4: no number, only a limit (the forecaster's own chance of this, stated with the estimate: 40%); at least 5.7-fold (0.75 log units) between middle value and limit.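

In this assay, tert-butyl in place of bromo on an aromatic carbon gives an at least 5.0-fold higher number from compound 3 to compound 4 (0.69 log units; beyond the scatter), the first readable step among these compounds and the first to touch a group on the six-membered aromatic ring of carbon only. This place on the ring therefore responds to the change, with more compound tolerated with tert-butyl than with bromo. The full size of the step stays unknown because compound 4 gives only a limit: the limit of >= 400000 nM in this assay, at which 1 of the 4 values shown sits.

The compounds shown leave open how an amine or a carboxylic acid would read at this place. From the compounds shown here alone, whether tert-butyl elsewhere on that ring gives a like step also stays open.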